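The source may hold more compounds than are shown below. What is called first, only, known or untested is meant among the compounds shown, and "the series" means these compounds.

Working notes on the series, cytotoxicity.

Compound 1 `COc1cc(/C=C2\CN(C)C/C(=C\c3ccc(Cl)cc3)C2=O)cc(OC)c1OC` gives in an ADME assay on L02 cells (Homo sapiens) for cytotoxicity, read by MTT assay, with a stated time of 24 h (on this read-out lower numbers stand for stronger inhibition and higher numbers for weaker inhibition), a value of 14000 nM. Compound 2 `COc1cc(/C=C2\CN(C)C/C(=C\c3ccc(Br)cc3)C2=O)cc(OC)c1OC` gives in this assay a value of 15400 nM. The change bromo in place of chloro on an aromatic carbon thus yields a 1.1-fold higher number from compound 1 to compound 2 (0.04 log units; within the scatter).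

Compound 3 `CN1C/C(=C\c2ccc(Cl)cc2)C(=O)/C(=C/c2cccc([N+](=O)[O-])c2)C1` carries a different core; how it differs from the core of compound 1 is not broken down here. In this assay compound 3 gives only a limit, > 20000 nM.

Compound 4 `CN1C/C(=C\c2ccc(Br)cc2)C(=O)/C(=C/c2cccc([N+](=O)[O-])c2)C1` is not yet measured. Against compound 3 it shows bromo in place of chloro on an aromatic carbon: the same change as between compound 1 and compound 2, at the same kind of place, word for word. The step is expected to be a step that the limit leaves unreadable from compound 3 to compound 4, matching a 1.1-fold higher number from compound 1 to compound 2 (0.04 log units; within the scatter) seen earlier. Compound 4 is therefore estimated at 24000 nM, resting on compound 3 sitting at the limit of > 20000 nM in this assay, at which 1 of the 3 values shown sits. The expected range for compound 4 runs from 12000 nM to 60000 nM.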

Compound 4, half-maximal inhibitory concentration: 9850 nM
For compound 4 the middle estimate is 2.4-fold (0.39 log units) above the measured one; the measured number lies below the stated range.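

Bromo in place of chloro on the core of compound 3 gives in this assay an at least 2.0-fold lower number from compound 3 to compound 4 (0.30 log units; that floor lies within the scatter). Set beside the earlier step, this neither shows that the change carries over unaltered from one core to the other nor shows that it behaves differently on the two cores: the same change on two cores in this assay, a 1.1-fold higher number (0.04 log units; within the scatter) from compound 1 to compound 2 and an at least 2.0-fold lower number (0.30 log units; that floor lies within the scatter) from compound 3 to compound 4; the limit leaves it open whether they differ For compound 3 the value > 20000 nM is a limit and not a number, and the true size of the step stays unread.

Open, as far as these compounds go, is whether fluoro or iodo at that place would follow either step. Also open, from the compounds shown here alone, is what an amine or a carboxylic acid at that place would give on either core.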